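Swapping a Sulfonamide Arm for a Nitrophenoxy Arm

A few compounds are considered here, and "the series" means these few. Any claim that something is new, unique, unknown or untested is made for them only; others in the source may bear on it.

Compound 3, `CC(C)=CCC/C(C)=C/CC1Cc2c(OCCCNS(=O)(=O)c3ccc(Br)cc3)cc(=O)n(CCCO)c2CC1(C)C`, gives 0% in a functional assay on PANC-1 cells (Homo sapiens) for inhibition, read by MTT assay, with a stated time of 24 h, tested at 10 uM; on this read-out lower numbers stand for less inhibition and higher numbers for more inhibition at the one concentration tested (going by the name of the read-out). Compound 2, `CC(C)=CCC/C(C)=C/CC1Cc2c(OCCCNS(=O)(=O)c3ccc(C(F)(F)F)cc3)cc(=O)n(CCCO)c2CC1(C)C`, gives 0%, and compound 1, `CC(C)=CCC1Cc2c(OCCCNS(=O)(=O)c3ccc(Br)cc3)cc(=O)n(CCCO)c2CC1(C)C`, gives 3.7%. Compound 3 is level with compound 2 at the digits reported, and the step of a number 3.7 percentage points lower from compound 1 to compound 3 (within the scatter) stays within the scatter, so all three readings sit within the ordinary scatter of one another and none can be set apart from the rest.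

Compound 4, `CC(C)=CCC/C(C)=C/CC1Cc2c(OCCCOc3ccc([N+](=O)[O-])cc3)cc(=O)n(CCCO)c2CC1(C)C`, differs from compound 3 in one place: 4-nitrophenoxy in place of ((4-bromophenyl)sulfonyl)amino on a saturated chain carbon, three bonds along the chain from an oxygen on an aromatic ring. Within the data shown here, no measured step covers this exact change. Among the measured compounds shown here, the two known steps, a number 3.7 percentage points lower from compound 1 to compound 3 (within the scatter) on the side chain and no change at the digits printed from compound 2 to compound 3 (within the scatter) on the aromatic ring of the sulfonyl group, both fall within the scatter, so nothing measured so far has moved this read-out. On that basis the expected step of a number 2 percentage points higher from compound 3 to compound 4 (within the scatter) is none beyond the scatter. Compound 4 is therefore estimated to give about 2%, with a likely range from 0% to 15%.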

Compound 4, a percentage reported as inhibition, at one concentration (the size of the read-out at that concentration, not a potency): 9.8%
The estimate for compound 4 lay 7.8 percentage points below the measured number; measured number inside the range.
By their numbers in this assay, from the lowest: compounds 2, 3, 1 and 4 (each within the scatter of the next).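

Exchanging ((4-bromophenyl)sulfonyl)amino for 4-nitrophenoxy alters the arm itself, not just a substituent on its aromatic ring or the side chain on the core. In this assay, this gives a number 9.8 percentage points higher from compound 3 to compound 4 (within the scatter), so even this larger exchange cannot be told apart from compound 3. The position therefore accepts a change from 1 hydrogen-bond donor to 0 and from a sulfonyl-linked ring to an oxygen-linked ring with no reading beyond the scatter, although no other measurement is available to explain this result.

Still open, from the compounds shown here alone, is whether an amine or a carboxylic acid in this place, or a longer chain leading to the aromatic ring, would give a reading beyond the scatter. Going by these compounds, it is also open whether 4-nitrophenoxy would behave the same way on the core of compound 1.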